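This account rests on a few compounds, and the source may have more. Where it says the series, first, only, none or still open, it means among the compounds named here.

Compound 1 `O=C(O)c1cccnc1Nc1ccc(OC(F)(F)F)cc1`: 7700 nM
Compound 2 `COc1ccc(C(=O)NCCC(=O)N[C@@H]2CCCc3ccccc32)cc1`: 5100 nM

In a functional assay on THP-1 cells (Homo sapiens) for activation, read by flow cytometry, with a stated time of 4 days (on this read-out higher numbers stand for an effect only at larger amounts of compound and lower numbers for an effect already at smaller amounts), compound 2 gives 5100 nM and compound 1 gives 7700 nM. Within the data shown here, these two numbers lie within the usual scatter of each other, so compound 2 cannot be separated from the only other measured compound. Both sit in the same broad range.

The next compound to be tested is compound 3 `O=C(CCNC(=O)c1ccc(Cl)c(Cl)c1)N[C@@H]1CCCc2ccccc21`. It has 3,4-dichlorophenyl in place of 4-methoxyphenyl on a carbonyl carbon, and the rest of compound 2 stays as it is: 3,4-dichlorophenyl in place of 4-methoxyphenyl on a carbonyl carbon. The two groups are the same size by heavy-atom count, and each is a single aromatic ring.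

Among the measured compounds shown here, no two measured compounds differ in only one place, so the data contain no direct precedent for this swap. The expectation in this assay is therefore only a small move toward a lower number, not clearly beyond the scatter. The step expected is a 1.7-fold lower number from compound 2 to compound 3 (0.23 log units; within the scatter). For compound 3 the estimated value is 3000 nM, with an expected range of 1000 nM to 9000 nM.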

Compound 3, half-maximal effective concentration: 2500 nM
For compound 3 the middle estimate is 1.2-fold (0.08 log units) above the measured one; low and high end bracket the measured number.
By their numbers in this assay, from the lowest: compound 3; then compounds 2 and 1 (each within the scatter of the next).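

Among these compounds, compound 2 and compound 3 give the first comparison in this assay between compounds that differ in one place. On a carbonyl carbon whose other neighbours are an amide-type nitrogen, 3,4-dichlorophenyl in place of 4-methoxyphenyl gives a 2.0-fold lower number from compound 2 to compound 3 (0.31 log units; beyond the scatter), a modest step, but it shows that the number responds to a change at this position even though the rest of the molecule stays the same and the heavy-atom count and the single aromatic ring are shared by both groups. The hydrogen-bond acceptor count falls with this swap and the number does not rise, yet no measurement of any property of these groups accompanies the step, so what lies behind it stays unknown.

One swap replaces the methoxy group and brings in two chlorines at once, so the compounds shown cannot tell whether a single chlorine would give the same number or whether removing the methoxy group matters more. They also leave open how an amine or a nitrile on this ring would behave, and what a longer chain between the two amide groups would do.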